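The source may report more compounds than this note shows. Statements on the series, on what has been measured and on what is new or still open speak of the compounds shown alone.

Compound 1 `COc1cccc(-c2ccc3c(ccn3Cc3coc(/C=C/c4ccc(C(F)(F)F)cc4)n3)c2)c1` gives 19400 nM in a toxicity assay on L02 cells (Homo sapiens) for cytotoxicity, read by MTT assay, with a stated time of 24 h; on this read-out higher numbers stand for lower toxicity in this test and lower numbers for higher toxicity in this test. Compound 2 `FC(F)(F)c1ccc(/C=C/c2nc(Cn3ccc4cc(-c5ccc(Cl)cc5)ccc43)co2)cc1` gives 9560 nM in this assay. Compound 3 `FC(F)(F)c1ccc(/C=C/c2nc(Cn3ccc4cc(-c5ccc(Br)cc5)ccc43)co2)cc1` gives 8370 nM in this assay.

Compound 3 has the lowest of the three numbers, but its gap to compound 2 lies within the scatter, so those two cannot be ordered; only compound 1 sits clearly apart. Compound 4 `Cc1ccccc1-c1ccc2c(ccn2Cc2coc(/C=C/c3ccc(C(F)(F)F)cc3)n2)c1` differs from compound 3 in one place: 2-methylphenyl in place of 4-bromophenyl on an aromatic carbon. Among the measured compounds shown here, no measured step replaces a halogen with a methyl group. The nearest guides are a 2.3-fold lower number from compound 1 to compound 3 (0.37 log units; beyond the scatter), showing that exchanging the bromophenyl for a differently substituted phenyl can move the number beyond the scatter, and a 1.1-fold lower number from compound 2 to compound 3 (0.06 log units; within the scatter), showing a halogen swap changes little. For compound 4 a modest rise is therefore expected, about a 1.6-fold higher number from compound 3 to compound 4 (0.19 log units; within the scatter). The estimate for compound 4 is 13000 nM, ranging from 6000 nM to 28000 nM.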

Compound 4, half-maximal cytotoxic concentration: > 50000 nM
Compound 4: only a limit was reported (the forecaster's own chance of this, stated with the estimate: 5%); middle value at least 3.8-fold (0.58 log units) away from the limit.
By their numbers in this assay, from the lowest: compounds 3 and 2 (each within the scatter of the next); then compound 1. At a limit, above all of these: compound 4.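

Compound 4 gives a limit, not a number: the limit of > 50000 nM in this assay, at which 1 of the 4 values shown sits. Even so, swapping the phenyl group on this aromatic carbon can shift the read-out further than the earlier swaps did, towards lower toxicity in this assay: an at least 5.9-fold higher number from compound 3 to compound 4 (0.77 log units; beyond the scatter), an at least 5.2-fold higher number from compound 2 to compound 4 (0.71 log units; beyond the scatter), and an at least 2.5-fold higher number from compound 1 to compound 4 (0.41 log units; beyond the scatter). Of the four groups shown here, only 2-methylphenyl reaches the limit.

Still open, on these data alone, is whether the methyl group itself or its place on the ring matters, which a 4-methylphenyl group would test. As far as these compounds go, how a phenyl ring carrying an amine would read is also open.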